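Cytotoxicity notes: aryl swap on the hydrazone carbon

A few compounds are considered here, and "the series" means these few. Any claim that something is new, unique, unknown or untested is made for them only; others in the source may bear on it.

The series shares one core; compound 2 `COc1ccccc1-c1nnc(-c2ccc(C(=O)N/N=C/c3ccc([N+](=O)[O-])cc3)cc2)o1` carries a 4-nitrophenyl on a carbon with a double bond to nitrogen, compound 1 `COc1ccccc1-c1nnc(-c2ccc(C(=O)N/N=C/c3ccncc3)cc2)o1` a pyridin-4-yl and compound 3 `COc1ccccc1-c1nnc(-c2ccc(C(=O)N/N=C/c3cccc(O)c3)cc2)o1` a 3-hydroxyphenyl. In an ADME assay on THP-1 cells (Homo sapiens) for cytotoxicity (a lower number here means a stronger inhibitor, a higher number a weaker inhibitor), compound 2 gives 203000 nM, compound 1 gives 173000 nM and compound 3 gives 398000 nM. Compound 2 stands between the other two, with a 1.2-fold higher number from compound 1 to compound 2 (0.07 log units; within the scatter) and a 2.0-fold higher number from compound 2 to compound 3 (0.29 log units; within the scatter), so it is not separated from either neighbour; only a 2.3-fold higher number from compound 1 to compound 3 (0.36 log units; beyond the scatter) reaches beyond the scatter, and that step is modest.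

Compound 4 `COc1ccccc1-c1nnc(-c2ccc(C(=O)N/N=C/c3ccccc3F)cc2)o1` differs from compound 2 as follows: 2-fluorophenyl in place of 4-nitrophenyl on a carbon with a double bond to nitrogen. All three measured steps change the aryl group at this same carbon, and none moves the number far in this assay. The 2-fluorophenyl change is therefore expected to give no step beyond the scatter, a 1.0-fold higher number from compound 2 to compound 4 (0.01 log units; within the scatter), in either direction. Compound 4 is estimated at 210000 nM, with a range from 110000 nM to 420000 nM.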

Compound 4, half-maximal inhibitory concentration: 313000 nM
Beside the measured number, compound 4's estimate is 1.5-fold (0.17 log units) below it, and the stated range covers the measured number.
By their numbers in this assay, from the lowest: compounds 1, 2, 4 and 3 (each within the scatter of the next, the first and the last beyond it).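

The 2-fluorophenyl group, the only one of the four aryl groups here that carries fluorine, shows no separation from any earlier aryl group on this carbon in this assay (a 1.5-fold higher number from compound 2 to compound 4 (0.19 log units; within the scatter)) (a 1.3-fold lower number from compound 3 to compound 4 (0.10 log units; within the scatter)) (a 1.8-fold higher number from compound 1 to compound 4 (0.26 log units; within the scatter)). Among these compounds, replacing a group with 2 hydrogen-bond acceptors by one with 0 therefore gives no step beyond the scatter, and compound 1 and compound 3 remain the only pair separated beyond it. No data on hand account for the differences seen at this position.

Still open, going by these compounds, is whether 3-fluorophenyl or 4-fluorophenyl would behave like 2-fluorophenyl. Also open, on these data alone, is whether an amine or a carboxylic acid on the phenyl ring, or a saturated alkyl chain in place of the aryl group, would give a larger step.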